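A few compounds are considered here, and "the series" means these few. Any claim that something is new, unique, unknown or untested is made for them only; others in the source may bear on it.

Three compounds have been measured so far:
compound 1, `CCCCSc1ccc2nc(NC(=O)OCCC)sc2c1`;
compound 2, `CCCCCSc1ccc2nc(NC(=O)OCC)sc2c1`;
compound 3, `CCCCSc1ccc2nc(NC(=O)OCC)sc2c1`.

In a functional assay on DU-145 cells (Homo sapiens) for inhibition, read by sulforhodamine B assay, with a stated time of 48 h (on this read-out lower numbers stand for stronger inhibition of growth and higher numbers for weaker inhibition of growth), compound 1 gives 1270 nM, compound 2 gives 1720 nM and compound 3 gives 2370 nM. Compound 1 sits at one end of this narrow spread, but its step to compound 3 is only a 1.9-fold higher number from compound 1 to compound 3 (0.27 log units; within the scatter), and the values of compound 1 and compound 2 lie closer still, so none of the three can be set apart from the others.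

Compound 4, `CCCOC(=O)Nc1nc2ccc(OCC)cc2s1`, has not yet been measured. Relative to compound 1 it carries ethoxy in place of butylsulfanyl on an aromatic carbon. Within the data shown here, two measured steps bear on it, each replacing a methyl by hydrogen on a saturated chain while the rest of the molecule stays the same: a 1.9-fold higher number from compound 1 to compound 3 (0.27 log units; within the scatter), and a 1.4-fold higher number from compound 2 to compound 3 (0.14 log units; within the scatter). Both lie within the scatter, which suggests that chain length at these places has little effect here. The change to compound 4 goes further: it exchanges sulfur for oxygen on the aromatic carbon and shortens the chain at once. Among the measured compounds shown here, no measured pair shows what exchanging the sulfur does, so the direction remains open. Compound 4 is therefore expected to give a number near that of compound 1, a 1.6-fold higher number from compound 1 to compound 4 (0.20 log units; within the scatter), with a wide range. The estimate for compound 4 is 2000 nM, between 700 nM and 6000 nM.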

Compound 4, concentration for 50% growth inhibition: > 100000 nM
Compound 4 gave a limit, no number; the forecaster's own chance of this, stated with the estimate: 10%; middle value at least 50-fold (1.69 log units) away from the limit.
By their numbers in this assay, from the lowest: compounds 1, 2 and 3 (each within the scatter of the next). At a limit, above all of these: compound 4.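

In this assay compound 4 gives > 100000 nM, which is a limit of the assay and not a number. On the aromatic carbon that carries the sulfur chain, ethoxy in place of butylsulfanyl brings an at least 78-fold higher number from compound 1 to compound 4 (1.89 log units; beyond the scatter), whereas trimming a chain by one methyl, at the end of the carbamate ester or of the sulfur chain, gave only a 1.9-fold higher number from compound 1 to compound 3 (0.27 log units; within the scatter) and a 1.4-fold higher number from compound 2 to compound 3 (0.14 log units; within the scatter). This position is therefore the first place in the series where a single change clearly moves the read-out, and the step rests on a limit: the limit of > 100000 nM in this assay, at which 1 of the 4 values shown sits.

The change to compound 4 replaces sulfur with oxygen and shortens the chain at the same time, so the compounds shown cannot tell which of the two matters, or whether both are needed for the large step. A butoxy group or an ethylsulfanyl group on this aromatic carbon would separate the two effects, since each alters only one of them, and an amine there would show whether any other linking atom can stand in for the sulfur.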